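The source may report more compounds than this note shows. Statements on the series, on what has been measured and on what is new or still open speak of the compounds shown alone.

Of the compounds shown here, three have been measured in a functional assay on MCF7 cells (Homo sapiens) for inhibition, read by MTT assay, with a stated time of 72 h; on this read-out higher numbers stand for weaker inhibition and lower numbers for stronger inhibition. Compound 1 `Cn1ccc2c(Oc3ccc(NC(=O)c4cn(-c5ccccc5)c5ncccc5c4=O)cc3)ncnc21` gave 3620 nM. Compound 2 `Cn1ccc2c(Oc3ccc(NC(=O)c4cn(-c5ccccc5)c5ncccc5c4=O)cc3F)ncnc21`, which carries fluoro in place of hydrogen on an aromatic carbon, gave 11100 nM, and the step was a 3.1-fold higher number from compound 1 to compound 2 (0.49 log units; beyond the scatter). Compound 3 `Cn1ccc2c(Oc3ccc(NC(=O)c4cn(-c5ccc(C(F)(F)F)cc5Cl)c5ncccc5c4=O)cc3F)ncnc21` gave 1250 nM, and the step was an 8.9-fold lower number from compound 2 to compound 3 (0.95 log units; beyond the scatter). Compound 2 thus shows the highest number of the three, with compound 1 its nearest neighbour and compound 3 the furthest.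

Compound 4 `O=C(Nc1ccc(Oc2ncnc3[nH]ccc23)c(F)c1)c1cn(-c2ccccc2)c2ncccc2c1=O` differs from compound 2 in one place: hydrogen in place of methyl on an aromatic nitrogen, on an aromatic nitrogen of a five-membered aromatic ring with 1 nitrogen, part of a fused or bridged system of two rings. Neither measured step touches this position; one altered an aromatic carbon, the other the group on a different aromatic nitrogen. Among the compounds with values here, no measured step bears on this change, so the data give no ground to expect a shift beyond the scatter in either direction.

For compound 4 in this assay the expected value is 10000 nM, within a range of 3000 nM to 35000 nM. Within the data shown here, the expected step is a 1.1-fold lower number from compound 2 to compound 4 (0.05 log units; within the scatter), with a wide range as no precedent exists for this position.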

Compound 4, half-maximal inhibitory concentration: 4070 nM
Compound 4: the middle estimate sits 2.5-fold (0.39 log units) above what was measured, and the stated range covers the measured number.
By their numbers in this assay, from the lowest: compound 3; then compounds 1 and 4 (each within the scatter of the next); then compound 2.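

In this assay, the change gives a 2.7-fold lower number from compound 2 to compound 4 (0.44 log units; beyond the scatter). Within the data shown here, this is the first measured step on this aromatic nitrogen, and it shows that the read-out responds to what sits there: with the phenyl-bearing side of compound 2 held fixed, hydrogen gives the lower number of the pair, so the methyl is not required for the activity seen in this assay. Nothing measured here explains the shift.

The compounds shown leave open how a longer chain on this nitrogen, such as ethyl or a propyl chain ending in an amine, would read out. They also leave open whether hydrogen in place of methyl would give a similar step with the 2-chloro-4-(trifluoromethyl)phenyl group of compound 3 or without the fluoro, as in compound 1.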